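This account rests on a few compounds, and the source may have more. Where it says the series, first, only, none or still open, it means among the compounds named here.

Measured so far in a functional assay on KYSE-450 cells (Homo sapiens) for inhibition, read by CCK-8 assay, with a stated time of 48 h; on this read-out lower numbers stand for stronger inhibition and higher numbers for weaker inhibition:
compound 1 `COc1ccc(CN(C(=O)CSC(=S)N2CCN(C(=O)OC(C)(C)C)CC2)c2cc(OC)c(OC)c(OC)c2)cc1F` gives 2410 nM
compound 2 `COc1ccc(CN(C(=O)CSC(=S)N2CCN(C(=O)OC(C)(C)C)CC2)c2cc(OC)c(OC)c(OC)c2)cc1[N+](=O)[O-]` gives 810 nM

Among the measured compounds shown here, compound 2 holds the lower of these two numbers, and compound 1 is its only measured neighbour. Next in the series is compound 3 `COc1ccc(CN(C(=O)CSC(=S)N2CCN(C(=O)OC(C)(C)C)CC2)c2cc(OC)c(OC)c(OC)c2)cc1O`, which differs from compound 2 as follows: hydroxy in place of nitro on an aromatic carbon (hydroxy in place of nitro on an aromatic carbon, ortho to a methoxy group). For the measured compounds named here, one measured step bears on this carbon, the one with nitro in place of fluoro. That step, a 3.0-fold lower number from compound 1 to compound 2 (0.47 log units; beyond the scatter) in the notes, is modest but beyond the scatter. Going by the values given here, no measured compound carries hydroxy, so the data fix no direction for the new exchange. A shift of similar modest size either way in this assay would not be surprising, and the central expectation is no change beyond the scatter. The expected step is a 1.0-fold lower number from compound 2 to compound 3 (0.01 log units; within the scatter) and carries a wide margin. For compound 3 the estimated value is 800 nM with an expected range from 200 nM to 3000 nM (an estimate only).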

Compound 3, half-maximal inhibitory concentration: 76 nM
Beside the measured number, compound 3's estimate is 11-fold (1.02 log units) above it; measured number below the stated range.
By their numbers in this assay, from the lowest: compound 3; then compound 2; then compound 1.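

In this assay, the aromatic carbon ortho to a methoxy group proves far more sensitive to its substituent than the first exchange suggested: hydroxy in place of nitro gives an 11-fold lower number from compound 2 to compound 3 (1.03 log units; beyond the scatter), and hydroxy in place of fluoro gives a 32-fold lower number from compound 1 to compound 3 (1.50 log units; beyond the scatter), both large beside the modest 3.0-fold lower number from compound 1 to compound 2 (0.47 log units; beyond the scatter). Compound 3 therefore holds the lowest number of the three, and among the groups compared at this carbon, only its hydroxy carries a hydrogen-bond donor, although one compound cannot tie the result to that count. No measurement in hand accounts for the size of this change.

From the compounds shown here alone, what remains open is whether the gain belongs to hydroxy specifically or would also appear with another group at this carbon, such as an amine, a methoxy group or a hydroxymethyl chain. Also open, going by these compounds, is whether hydroxy keeps this advantage when the rest of the core changes, for instance when the tert-butyl carbamate gives way to an amide or a free piperazine amine.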